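Bromo to methyl on the pendant phenyl of compound 1

This account rests on a few compounds, and the source may have more. Where it says the series, first, only, none or still open, it means among the compounds named here.

Measured so far in a functional assay on A549 cells (Homo sapiens) for antiproliferative activity, read by XTT assay, with a stated time of 24 h; on this read-out higher numbers stand for weaker inhibition and lower numbers for stronger inhibition:
- compound 1 `Fc1ccc(C2CC(c3ccc(Cl)s3)=NN2c2nc(-c3ccc(Br)cc3)cs2)cc1`: 62.5 ug/mL
- compound 2 `Cc1ccc(C2=NN(c3nc(-c4ccc(Cl)cc4)cs3)C(c3ccc(F)cc3)C2)s1`: reported only as a limit, > 500 ug/mL
- compound 3 `COc1ccc(-c2csc(N3N=C(c4ccc(C)s4)CC3c3ccc(F)cc3)n2)cc1`: 184 ug/mL

Compound 1 holds the lowest of the two numbers; compound 3 sits about an at least 2.7-fold lower number from compound 2 to compound 3 (0.43 log units; beyond the scatter) away in size terms from the limit of compound 2, and compound 1 lies a further step below compound 3, beyond the scatter. Compound 2 is one of those sitting at the limit of > 500 ug/mL in this assay, at which 1 of the 3 values shown sits.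

Compound 4 `Cc1ccc(-c2csc(N3N=C(c4ccc(Cl)s4)CC3c3ccc(F)cc3)n2)cc1` differs from compound 1 by methyl in place of bromo on an aromatic carbon. Going by the values given here, the only measured step on this same phenyl is an at least 2.7-fold lower number from compound 2 to compound 3 (0.43 log units; beyond the scatter), where a halogen gave way to methoxy and the number fell. Here a halogen gives way to methyl, and compounds 2 and 3 also carry a different group on the thiophene than compound 1, so that step is only a loose guide. A step within the scatter, or at most modest and toward lower numbers, is expected in this assay. Compound 4 is therefore estimated at 60 ug/mL, between 25 ug/mL and 200 ug/mL, which means an expected step of a 1.0-fold lower number from compound 1 to compound 4 (0.02 log units; within the scatter).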

Compound 4, half-maximal inhibitory concentration: > 500 ug/mL
Compound 4 was reported as a limit; the forecaster's own chance of this, stated with the estimate: 10%; at least 8.3-fold (0.92 log units) between middle value and limit.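

In this assay the change from 4-bromophenyl to 4-methylphenyl gives an at least 8.0-fold higher number from compound 1 to compound 4 (0.90 log units; beyond the scatter) with the chloro on the thiophene held fixed. The earlier step on this phenyl came from compounds with methyl on the thiophene, so the present pair shows that the same position also responds when the thiophene carries chloro, and that methyl does not stand in for bromo here. Compound 4 is reported only as a limit, so this step has a lower bound and no measured size: the limit of > 500 ug/mL in this assay, at which 2 of the 4 values shown sit.

From the compounds shown here alone, whether methoxy on this phenyl would also keep a measurable number with chloro on the thiophene stays open. Also open, going by these compounds, is whether an amine or a carboxylic acid in place of bromo would hold the number near that of compound 1, which gives 62.5 ug/mL in this assay on this read-out.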